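Shortening a side chain on an adenosine-like scaffold

This account rests on a few compounds, and the source may have more. Where it says the series, first, only, none or still open, it means among the compounds named here.

Three compounds share a nucleoside-type core. Compound 1 `OC[C@]1(O)CO[C@@H](n2cnc3c(NCc4cccc(I)c4)ncnc32)[C@@H]1O` gives 35% in an assay on CHO cells for displacement of a labelled ligand from adenosine receptor A1 (Homo sapiens), tested at 10 uM; a higher number here means more inhibition at the concentration tested (going by the name of the read-out), a lower number less inhibition. Compound 2 `CCNC(=O)OC[C@@H]1CO[C@@H](n2cnc3c(N)ncnc32)[C@@H]1O` gives 7% in this assay, and compound 3 `CCNC(=O)OC[C@]1(O)CO[C@@H](n2cnc3c(N)ncnc32)[C@@H]1O` gives 9%. Compound 2 has the lowest of the three numbers; its gap to compound 3 lies within the scatter, while compound 1 sits beyond the scatter above it.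

Compound 4 `CCNC(=O)[C@@H]1CO[C@@H](n2cnc3c(N)ncnc32)[C@@H]1O` has not been measured. It differs from compound 2 in one place: ethylcarbamoyl in place of ((ethylcarbamoyl)oxy)methyl on a saturated ring carbon. For the measured compounds named here, no measured pair shows what such a change does, so the expectation rests on analogy alone. Compound 4 is expected to show a modest rise, a step of a number 11 percentage points higher from compound 2 to compound 4 (beyond the scatter) in this assay. The estimate for compound 4 is 18%, with a range from 4% to 45%.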

Compound 4, a percentage reported as inhibition, at one concentration (the size of the read-out at that concentration, not a potency): 8%
The estimate for compound 4 lay 10 percentage points above the measured number; low and high end bracket the measured number.
By their numbers in this assay, from the lowest: compounds 2, 4 and 3 (each within the scatter of the next); then compound 1.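

Swapping ((ethylcarbamoyl)oxy)methyl for ethylcarbamoyl on this saturated ring carbon gives a number 1 percentage points higher from compound 2 to compound 4 (within the scatter) in this assay. This first one-place comparison therefore shows that, at this single concentration, the smaller side chain leaves the read-out unchanged within the scatter. Nothing available explains this result.

Still open, on these data alone, is whether a different group on this ring carbon, such as a carboxylic acid, an amine or a longer chain, would shift the number beyond the scatter.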